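The source may report more compounds than this note shows. Statements on the series, on what has been measured and on what is new or still open speak of the compounds shown alone.

Compound 1 `C[C@@H]1O[C@@]1(C)Cc1cc(=O)n(C)c(=O)n1C`, compound 2 `Cn1c(OC2CCCCC2)nc(CC2(c3ccccc3)CO2)cc1=O` and compound 3 `CC1OC1(C)Cc1cc(=O)n(C)c(OC2CCCCC2)n1` were examined in a functional assay for inhibition, with Mus musculus as the target; a lower number here means that less compound is tolerated, a higher number that more compound is tolerated. In this assay compound 1 gives 89000 nM. For compound 2 the result in this assay is a limit of the assay rather than a number, > 294000 nM. For compound 3 the result in this assay is likewise a limit, > 342000 nM. Compound 2 thus stands at one of the two limits among the three results shown, namely (the limit of > 294000 nM in this assay, at which 1 of the 3 values shown sits), while compound 3 stands at the limit of > 342000 nM in this assay, at which 1 of the 3 values shown sits. No two of these compounds differ in only one place, so no single measured step can be drawn between them. Compound 4 `CCCOc1nc(CC2(c3ccccc3)CO2)cc(=O)n1C` is the compound not yet measured; it arises from compound 2 by propyl in place of cyclohexyl on an oxygen on an aromatic ring. With compound 2 known only as a limit, the numbers do not fix a direction for the change. For compound 4 the step expected in this assay is an at least 1.1-fold lower number from compound 2 to compound 4 (0.07 log units; that floor lies within the scatter), none beyond the usual scatter. Compound 4 is expected to give 250000 nM, between 80000 nM and 400000 nM.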

Compound 4, half-maximal cytotoxic concentration: > 30000 nM
Compound 4 was reported as a limit; the forecaster's own chance of this, stated with the estimate: 60%; the middle value is on the limit's open side.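

In this assay compound 4 is reported as a limit, > 30000 nM. Compound 2 is also known only as a limit, > 294000 nM. For the compounds shown here, no step can therefore be read between compound 2 and compound 4. The compounds shown leave open whether propyl in place of cyclohexyl on an oxygen on an aromatic ring changes the tolerated concentration at all.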